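This account rests on a few compounds, and the source may have more. Where it says the series, first, only, none or still open, it means among the compounds named here.

Measured so far:
compound 1 `Cc1ccc(C(=O)Nc2cccc(C(F)(F)F)c2)cc1-c1ccc2c(-c3ccc(N4CCN(C)CC4)cc3)n[nH]c2c1`: 89.5 nM
compound 2 `Cc1ccc(C(=O)Nc2cccc(C(F)(F)F)c2)cc1-c1ccc2c(-c3cnn(C)c3)n[nH]c2c1`: 24.3 nM

In a functional assay on NCI-H2286 cells (Homo sapiens) for antiproliferative activity, read by CCK-8 assay, with a stated time of 72 h (a higher number here means a weaker inhibitor, a lower number a stronger inhibitor), compound 2 gives 24.3 nM as the lower of the two numbers, and compound 1 stands above it by more than the scatter. Compound 3 `Cc1ccc(C(=O)Nc2cccc(C(F)(F)F)c2)cc1-c1ccc2c(-c3cnn(C4CC4)c3)n[nH]c2c1` differs from compound 2 by cyclopropyl in place of methyl on an aromatic nitrogen and has cyclopropyl in place of methyl on an aromatic nitrogen. Among the measured compounds shown here, no measured pair shows this change, so the direction stays open, and no step beyond the scatter is expected in this assay. Compound 3 is estimated at 27 nM with 10 nM to 70 nM as the expected range.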

Compound 3, half-maximal inhibitory concentration: 93 nM
Estimate against measurement, compound 3: 3.4-fold (0.54 log units) below; the measured number lies above the stated range.
By their numbers in this assay, from the lowest: compound 2; then compounds 1 and 3 (each within the scatter of the next).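

In this assay, among the compounds shown here, the change from 1-methyl-1H-pyrazol-4-yl to 1-cyclopropyl-1H-pyrazol-4-yl gives a 3.8-fold higher number from compound 2 to compound 3 (0.58 log units; beyond the scatter) and is the first single-place step. The substituent on this aromatic nitrogen therefore affects the antiproliferative number, and cyclopropyl is not interchangeable with methyl here. No available evidence accounts for this step.

One step cannot show whether the ring or the added carbons matter; ethyl or isopropyl on the same nitrogen would separate the two. Going by these compounds, how a hydrogen or a chain ending in an amine would behave at this nitrogen remains open.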